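Changing the fluorine pattern on the pendant phenyl ring

The source may report more compounds than this note shows. Statements on the series, on what has been measured and on what is new or still open speak of the compounds shown alone.

Of the compounds shown here, three share one core and have been tested in an assay on isolated protein for inhibition of tyrosine-protein kinase receptor UFO (Homo sapiens), read by ELISA; a lower number here means a stronger inhibitor, a higher number a weaker inhibitor. Compound 1 `Nc1ncnc2[nH]cc(-c3ccc(NC(=O)c4cn(CC5CCOCC5)cc(-c5ccc(F)cc5)c4=O)cc3)c12` gives 0.2 nM. Compound 2 `Cn1cc(-c2ccc(NC(=O)c3cn(CC4CCOCC4)cc(-c4ccc(F)cc4F)c3=O)cc2)c2c(N)ncnc21` gives 0.8 nM, the highest number of the three, and compound 3 `Cn1cc(-c2ccc(NC(=O)c3cn(CC4CCOCC4)cc(-c4ccc(F)cc4)c3=O)c(F)c2)c2c(N)ncnc21` gives 0.2 nM. Both compound 1 and compound 3 thus sit at a lower number than compound 2, by more than the usual scatter, so compound 2 is the weakest inhibitor of the three on these numbers. Compound 4 `Cn1cc(-c2ccc(NC(=O)c3cn(CC4CCOCC4)cc(-c4cccc(F)c4)c3=O)cc2)c2c(N)ncnc21` has not yet been measured. It differs from compound 2 in one place: 3-fluorophenyl in place of 2,4-difluorophenyl on an aromatic carbon. Going by the values given here, compound 1 and compound 3 each carry a single fluorine on that phenyl ring and both give a lower number than compound 2, although they also differ from it elsewhere, so no direct step is available. A modest move in this assay toward a stronger inhibitor is expected, roughly a 2.0-fold lower number from compound 2 to compound 4 (0.30 log units; within the scatter). Compound 4 is therefore estimated at 0.4 nM, within a range of 0.15 nM to 1.2 nM.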

Compound 4, half-maximal inhibitory concentration: 3 nM
Estimate against measurement, compound 4: 7.5-fold (0.88 log units) below; the whole stated range lies below it.
By their numbers in this assay, from the lowest: compounds 1 and 3 (each within the scatter of the next); then compound 2; then compound 4.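

In this assay, the swap of 2,4-difluorophenyl for 3-fluorophenyl gives a 3.8-fold higher number from compound 2 to compound 4 (0.57 log units; beyond the scatter), a step beyond the scatter toward a weaker inhibitor. Going by these compounds alone, this is the first direct comparison at this position on the shared core, and it shows that the fluorine pattern on this phenyl ring can change the number even when everything else stays fixed. The data offer no measured explanation for this shift.

Within the data shown here, the single step changes both the number of fluorines and where they sit, so it cannot show which of the two matters. On these data alone, whether the ring tolerates other groups also remains open: a plain phenyl, a 2-fluorophenyl or a methoxyphenyl at the same place would each test a different part of that question.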